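From 4-Chlorophenyl to 2-Fluorophenyl: a Small Step Expected

The source may hold more compounds than are shown below. What is called first, only, known or untested is meant among the compounds shown, and "the series" means these compounds.

Of the compounds shown here, two sharing one core have so far been measured in a physicochemical assay, with a stated time of 30 min; a lower number here means that less compound is needed, a higher number that more compound is needed for the effect. Compound 1 `C/C(=N\N=C1/SCC(=O)N1Cc1cccc(F)c1)c1cccs1` gives 2550000 nM in this assay. Compound 2 `O=C1CS/C(=N\N=C2CCCC2)N1Cc1ccc(Cl)cc1` gives 2100000 nM, the lower of the two numbers, although its nearest neighbour, compound 1, sits so close that the two values fall within the scatter of repeated measurements. Among the compounds with values here, no pair of measured compounds differs in a single place, so no step size has yet been observed in this assay.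

Compound 3 `O=C1CS/C(=N\N=C2CCCC2)N1Cc1ccccc1F` is the next to be measured in this assay. It differs from compound 2 in one place:

2-fluorophenyl in place of 4-chlorophenyl on a saturated chain carbon bound to an amide-type nitrogen in a ring

The two values already in hand sit within the scatter of each other. Within the data shown here, there is no observed step on which to anchor a direction, and nothing seen so far suggests a large shift. Compound 3 is therefore expected to give about 2300000 nM, in a range from 1000000 nM to 5500000 nM. The estimated step of a 1.1-fold higher number from compound 2 to compound 3 (0.04 log units; within the scatter) is expected to be no larger than the scatter, in neither direction.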

Compound 3, half-maximal effective concentration: 2370000 nM
Beside the measured number, compound 3's estimate is 1.0-fold (0.01 log units) below it; the range from low to high includes it.
By their numbers in this assay, from the lowest: compounds 2, 3 and 1 (each within the scatter of the next).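

In this assay, within the data shown here, this is the first step that can be read at all: 2-fluorophenyl in place of 4-chlorophenyl on a saturated chain carbon bound to an amide-type nitrogen in a ring gives a 1.1-fold higher number from compound 2 to compound 3 (0.05 log units; within the scatter). At this place, then, the two halogen-bearing phenyl groups cannot be told apart by this read-out, even though the halogen and its printed ring position both differ between them. Nothing measured bears on why the two groups read alike.

Among these compounds, the single step joins two differences in one change, so it cannot show whether the switch from chlorine to fluorine and the change of ring position would each be as small alone, or whether the same change would read the same way on the core of compound 1. It also leaves open whether this place can move the number beyond the scatter at all, since both groups compared here are halogen-bearing phenyl rings, and an amine, a carboxylic acid or a longer chain in their stead could give a quite different reading.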